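Benzoyl on the ring nitrogen across two amide cores

This account rests on a few compounds, and the source may have more. Where it says the series, first, only, none or still open, it means among the compounds named here.

Measured so far:
Compound 1, `O=C(Nc1ccccc1C(F)(F)F)C1CCc2ccccc2N1`: in a functional assay on MDA-MB-231 cells (Homo sapiens) for cytotoxicity, read by sulforhodamine B assay, with a stated time of 72 h (on this read-out lower numbers stand for stronger inhibition of growth and higher numbers for weaker inhibition of growth), compound 1 gives 45500 nM.
Compound 2, `O=C(Nc1ccccc1C(F)(F)F)C1CCc2ccccc2N1C(=O)c1ccccc1`: in this assay compound 2 gives 5290 nM.
Compound 3, `O=C(Nc1cc(C(F)(F)F)cc(C(F)(F)F)c1)C1CCc2ccccc2N1`: in this assay compound 3 gives 8270 nM.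

Compound 4, `O=C(Nc1cc(C(F)(F)F)cc(C(F)(F)F)c1)C1CCc2ccccc2N1C(=O)c1ccccc1`, has not yet been measured in this assay. It differs from compound 3 by benzoyl in place of hydrogen on a nitrogen on an aromatic ring in a ring. The same change has been made once already, from compound 1 to compound 2, where it is benzoyl in place of hydrogen on a nitrogen on an aromatic ring in a ring, and there it gave an 8.6-fold lower number from compound 1 to compound 2 (0.93 log units; beyond the scatter). How the core of compound 1 and the core of compound 3 differ is not broken down here. Compound 3 sits nearest to compound 2, within the scatter of that value, and beyond the scatter from compound 1.

For the measured compounds named here, for compound 4 the expectation is a step of about a 6.9-fold lower number from compound 3 to compound 4 (0.84 log units; beyond the scatter) in this assay, resting on the single earlier benzoyl step an 8.6-fold lower number from compound 1 to compound 2 (0.93 log units; beyond the scatter); one example gives no measure of how far that step carries onto a core where compound 3 already stands at 8270 nM, so the range is kept wide. Compound 4 is estimated at 1200 nM, between 400 nM and 4000 nM.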

Compound 4, concentration for 50% growth inhibition: 2430 nM
Estimate against measurement, compound 4: 2.0-fold (0.31 log units) below; the range from low to high includes it.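

In this assay benzoyl in place of hydrogen on the ring nitrogen again gives a step beyond the scatter, here a 3.4-fold lower number from compound 3 to compound 4 (0.53 log units; beyond the scatter). Set beside the earlier step, the two sizes cannot be told apart: the same change on two cores in this assay, an 8.6-fold lower number (0.93 log units; beyond the scatter) from compound 1 to compound 2 and a 3.4-fold lower number (0.53 log units; beyond the scatter) from compound 3 to compound 4, 2.5-fold (0.40 log units) apart, within the scatter of two such steps. The direction of the change therefore carries from the core of compound 1 to the core of compound 3 and no difference in size can be claimed, but two cores are a narrow base, and the pair shows neither why the step occurs nor whether it would hold on any other core.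

Open, on these data alone, is whether a smaller acyl group such as acetyl, a longer alkyl chain, or a benzoyl ring bearing an amine or a carboxylic acid would give a step of like size on that nitrogen. Also open, as far as these compounds go, is whether the step survives with a nitrile in place of trifluoromethyl on the amide side.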